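The source may report more compounds than this note shows. Statements on the series, on what has been measured and on what is new or still open speak of the compounds shown alone.

Measured in a functional assay on HCT-116 cells (Homo sapiens) for antiproliferative activity, read by WST assay, with a stated time of 72 h; on this read-out higher numbers stand for weaker inhibition of growth and lower numbers for stronger inhibition of growth:

- Compound 1 `O=C(NO)c1cnc(N2C[C@@H]3[C@H](C2)[C@H]3NCc2ccc(OC(F)(F)F)cc2)nc1`: 120 nM
- Compound 2 `CCCCc1ccc(CN[C@H]2[C@@H]3CN(c4ncc(C(=O)NO)cn4)C[C@@H]32)cc1`: 410 nM

Compound 2 has the higher of these two numbers, so it is the weaker growth inhibitor of the pair, and the gap lies beyond the scatter. Compound 3 `O=C(NO)c1cnc(N2C[C@@H]3[C@H](C2)[C@H]3NCc2ccc(Oc3ccccc3)cc2)nc1` keeps the rest of compound 2 and changes one group: phenoxy in place of butyl on an aromatic carbon, para to a large group (phenoxy in place of butyl on an aromatic carbon).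

Within the data shown here, only one measured step bears on this change. It is a 3.4-fold higher number from compound 1 to compound 2 (0.53 log units; beyond the scatter), a modest step made by exchanging a group at that same place. Trifluoromethoxy and phenoxy both attach to the ring through oxygen, whereas butyl attaches through carbon. The better value of compound 1, 120 nM, therefore gives a cautious reason to expect a move back towards a lower number, though one step is thin evidence. A modest drop is expected, no larger than the measured step and possibly within the scatter. The estimated change is a 2.1-fold lower number from compound 2 to compound 3 (0.31 log units; beyond the scatter). For compound 3 the estimate is 200 nM, with an expected range of 70 nM to 550 nM.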

Compound 3, concentration for 50% growth inhibition: 120 nM
The estimate for compound 3 lay 1.7-fold (0.22 log units) above the measured number; low and high end bracket the measured number.
By their numbers in this assay, from the lowest: compounds 1 and 3 (each within the scatter of the next); then compound 2.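

In this assay, putting phenoxy in place of butyl at this place on the aromatic ring gives a 3.4-fold lower number from compound 2 to compound 3 (0.53 log units; beyond the scatter) and so reverses the loss seen with butyl, this time with a group that brings a second six-membered aromatic ring. Changing only what sits on the oxygen, with phenyl in place of trifluoromethyl, gives no change at the digits printed from compound 1 to compound 3 (within the scatter) in the same test, so this position takes an oxygen-linked group with or without an aromatic ring and the two compounds cannot be told apart here. Among these three compounds, the two with an oxygen-linked group both have lower numbers than the butyl compound, but no measurement shown here explains that difference.

These compounds leave open whether the oxygen link, rather than the size or shape of the group, separates compound 2 from compound 3: a butoxy group would keep the chain and add the oxygen, while a benzyl group would keep the ring and replace the oxygen with carbon. As far as these compounds go, it also remains open how a group of a different kind, such as an amine or a carboxylic acid, would fare at this position.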